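The source may report more compounds than this note shows. Statements on the series, on what has been measured and on what is new or still open speak of the compounds shown alone.

Measured so far in a functional assay on HEK293 cells for antagonist activity at thromboxane A2 receptor (Homo sapiens), read by fluorescence and calcium flux; on this read-out lower numbers stand for stronger inhibition and higher numbers for weaker inhibition:
Compound 1, `CC(C)NC(=O)NS(=O)(=O)c1cc(C#N)ccc1Oc1ccc(Br)cc1`, where compound 1 gives 9130 nM.
Compound 2, `CC(C)(C)NC(=O)NS(=O)(=O)c1cc(C#N)ccc1Oc1ccc(Br)cc1`, where compound 2 gives 5310 nM.
Compound 3, `Cc1ccccc1Nc1ccc(C#N)cc1S(=O)(=O)NC(=O)NC(C)C`, where compound 3 gives 10100 nM.

Compound 4, `Cc1ccccc1Nc1ccc(C#N)cc1S(=O)(=O)NC(=O)NC(C)(C)C`, has not yet been measured. It stands to compound 3 as compound 2 stands to compound 1. The change from compound 3 to compound 4 is methyl in place of hydrogen on a saturated chain carbon bound to an amide-type nitrogen and two saturated chain carbons; the change from compound 1 to compound 2 is methyl in place of hydrogen on a saturated chain carbon bound to an amide-type nitrogen and two saturated chain carbons, and it gave a 1.7-fold lower number from compound 1 to compound 2 (0.24 log units; within the scatter). The place of the change reads the same in both pairs, so this is the same change. The two cores differ by (2-methylphenyl)amino in place of 4-bromophenoxy on an aromatic carbon, which gave a 1.1-fold higher number from compound 1 to compound 3 (0.04 log units; within the scatter). Among the compounds with values here, on the one measured instance of this change, compound 4 is expected to sit about a 1.7-fold lower number from compound 3 to compound 4 (0.23 log units; within the scatter) from compound 3, a single step that itself lies inside the scatter, so the basis is thin. The estimate for compound 4 in this assay is 6000 nM, expected to fall between 3000 nM and 12000 nM.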

Compound 4, half-maximal inhibitory concentration: 4780 nM
The estimate for compound 4 lay 1.3-fold (0.10 log units) above the measured number, within the range that was stated.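

In this assay, going from isopropyl to tert-butyl on the core of compound 3 gave a 2.1-fold lower number from compound 3 to compound 4 (0.32 log units; beyond the scatter), and this agrees with the same change on the core of compound 1: the same change on two cores in this assay, a 1.7-fold lower number (0.24 log units; within the scatter) from compound 1 to compound 2 and a 2.1-fold lower number (0.32 log units; beyond the scatter) from compound 3 to compound 4, 1.2-fold (0.09 log units) apart, within the scatter of two such steps. Exchanging 4-bromophenoxy for (2-methylphenyl)amino with tert-butyl in place gave a 1.1-fold lower number from compound 2 to compound 4 (0.05 log units; within the scatter), and this also matches the earlier reading of that exchange: the same change on two cores in this assay, a 1.1-fold higher number (0.04 log units; within the scatter) from compound 1 to compound 3 and a 1.1-fold lower number (0.05 log units; within the scatter) from compound 2 to compound 4, 1.2-fold (0.09 log units) apart, within the scatter of two such steps. Within the data shown here, the change therefore carried over between these two cores, but this rests on only two pairs, and only the step to compound 4 lies beyond the scatter, so it shows no general rule for other cores.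

The compounds shown leave open whether a cyclohexyl group or a longer chain in place of tert-butyl would give a similar step. They also leave open how the change behaves on a core carrying a benzylamino group instead of 4-bromophenoxy or (2-methylphenyl)amino.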